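Swapping an amide for a sulfonyl on a pyrazoline nitrogen

A few compounds are considered here, and "the series" means these few. Any claim that something is new, unique, unknown or untested is made for them only; others in the source may bear on it.

Measured compounds:
compound 1, `CN1CCN(c2ccc(C3=NN(C(=O)c4ccc(C(F)(F)F)cc4)C(c4ccc(N(C)C)cc4)C3)cc2)CC1`, 84.1%
compound 2, `CN1CCN(c2ccc(C3=NN(C(=O)/C=C/c4ccccc4)C(c4ccc(N(C)C)cc4)C3)cc2)CC1`, 71%

Both compounds were tested in a functional assay on HCC1806 cells (Homo sapiens) for inhibition, read by sulforhodamine B assay, tested at 10 uM; a higher number here means more inhibition at the concentration tested (going by the name of the read-out), a lower number less inhibition. Of the two numbers, compound 2 gives the lower one; the nearest is compound 1, whose value sits higher by the step of a number 13.1 percentage points lower from compound 1 to compound 2 (beyond the scatter). Among the measured compounds shown here, that step, a modest one beyond the scatter, is the only measured change and it concerns the group on the carbonyl carbon, not the carbonyl itself.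

Compound 3, `CN1CCN(c2ccc(C3=NN(S(=O)(=O)c4ccc(Br)cc4)C(c4ccc(N(C)C)cc4)C3)cc2)CC1`, has not yet been measured. Relative to compound 2 the change is (4-bromophenyl)sulfonyl in place of (2-phenylethenyl)carbonyl on an amine nitrogen in a ring. For the measured compounds named here, no measured step exchanges a carbonyl for a sulfonyl on this ring nitrogen, so the only guide is that compound 1 and compound 2 both show substantial inhibition while carrying an aryl or styryl acyl group there. For compound 3 the estimate is therefore 72% with a range of 45% to 92%. This amounts to an expected step of a number 1 percentage points higher from compound 2 to compound 3 (within the scatter), which is not expected to go beyond the scatter in either direction.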

Compound 3, a percentage reported as inhibition, at one concentration (the size of the read-out at that concentration, not a potency): 87.1%
Compound 3: middle estimate off by 15.1 percentage points, on the low side, and the stated range covers the measured number.
By their numbers in this assay, from the lowest: compound 2; then compounds 1 and 3 (each within the scatter of the next).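

In this assay, the (4-bromophenyl)sulfonyl group on the amine nitrogen in a ring matches the (4-(trifluoromethyl)phenyl)carbonyl group, with a number 3 percentage points higher from compound 1 to compound 3 (within the scatter), so a carbonyl on this nitrogen is not needed for inhibition at this level among the compounds shown. Against the (2-phenylethenyl)carbonyl group, the same sulfonyl group gives a number 16.1 percentage points higher from compound 2 to compound 3 (beyond the scatter), which leaves compound 2 apart from the other two compounds. Nothing available explains these differences.

The change from carbonyl to sulfonyl comes together with a change in the group it carries, so the compounds shown do not separate the effect of the sulfonyl from that of the bromine. Also open, going by these compounds, is how a simple methylsulfonyl group, or a (4-aminophenyl)sulfonyl group, on this nitrogen would read in this assay.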